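Anilino replacement on the ring amine of compound 1

The compounds below may be only part of what the source reports. "The series", "measured", "known", "first", "only" and "open" are said of these compounds alone.

Compound 1 `O=C1C(NC2CC2)=CC(=O)c2c1nc1n2[C@H]2OC[C@@H](O)[C@H]2OC1` carries a cyclopropylamino group on the shared core. In a functional assay on MCF7 cells (Homo sapiens) for inhibition, read by sulforhodamine B assay (on this read-out higher numbers stand for weaker inhibition and lower numbers for stronger inhibition), compound 1 gives > 16000 nM, which is a limit of the assay rather than a number. Compound 2 `O=C1C(N2CCCCC2)=CC(=O)c2c1nc1n2[C@H]2OC[C@@H](O)[C@H]2OC1` has piperidin-1-yl in place of cyclopropylamino on a double-bonded ring carbon. In this assay compound 2 gives > 8000 nM, also a limit. Among the measured compounds shown here, the only measured step, a step that the two limits leave unreadable from compound 1 to compound 2, therefore carries no readable size or direction, since compound 1 sits at the limit of > 16000 nM in this assay, at which 1 of the 2 values shown sits, and compound 2 sits at the limit of > 8000 nM in this assay, at which 1 of the 2 values shown sits. Compound 3 `O=C1C(Nc2ccc(C(F)(F)F)cc2)=CC(=O)c2c1nc1n2[C@H]2OC[C@@H](O)[C@H]2OC1` differs from compound 1 by 4-(trifluoromethyl)phenyl in place of cyclopropyl on an amine nitrogen. No measured step bears readably on this change, so no size or direction beyond the scatter can be drawn from the shown values in this assay. Compound 3 is expected to give 15000 nM in this assay, within 3000 nM to 60000 nM. The expected step is an at least 1.0-fold lower number from compound 1 to compound 3 (0.02 log units; that floor lies within the scatter).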

Compound 3, half-maximal inhibitory concentration: > 4000 nM
Compound 3: a limit, no number; the forecaster's own chance of this, stated with the estimate: 60%; the middle value lies beyond the limit too.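

Compound 1 and compound 3 both give only a limit in this assay, so the step between them cannot be read. The compounds shown leave open whether 4-(trifluoromethyl)phenyl in place of cyclopropyl on an amine nitrogen changes inhibition in either direction.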